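Dimethylamino in Place of Methoxy: Expected Growth Inhibition

A few compounds are considered here, and "the series" means these few. Any claim that something is new, unique, unknown or untested is made for them only; others in the source may bear on it.

Compound 2 `COc1ccc(/C=N\NC(=S)NC(C)(C)CCC[C@](C)(O)[C@@H]2CC=C(C)CC2)cc1` has the lower of the two numbers recorded so far in a functional assay on HT-29 cells (Homo sapiens) for cytotoxicity, read by sulforhodamine B assay (a higher number here means a weaker inhibitor of growth, a lower number a stronger inhibitor of growth), where compound 2 gives 7420 nM. Its nearest neighbour is compound 1 `CC1=CC[C@@H]([C@@](C)(O)CCCC(C)(C)NC(=S)N/N=C\c2ccccc2)CC1`, which in this assay gives 9960 nM. Going by the values given here, the only recorded step, a 1.3-fold lower number from compound 1 to compound 2 (0.13 log units; within the scatter), lies within the scatter, so nothing separates the two compounds beyond it. Compound 3 `CC1=CC[C@@H]([C@@](C)(O)CCCC(C)(C)NC(=S)N/N=C\c2ccc(N(C)C)cc2)CC1` carries the change (dimethylamino in place of methoxy on an aromatic carbon). Among the compounds with values here, no measured step involves a dimethylamino group, so the step with a methoxy group is the sole guide, and that step stayed within the scatter. A move from a methoxy group to a dimethylamino group on the same aromatic carbon is therefore expected to give, at most, a small step, and none beyond the scatter is the likeliest outcome. The estimate for compound 3 in this assay is 6500 nM, with a range from 2200 nM to 19000 nM. This corresponds to an expected step of a 1.1-fold lower number from compound 2 to compound 3 (0.06 log units; within the scatter).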

Compound 3, concentration for 50% growth inhibition: 27700 nM
Compound 3: middle estimate off by 4.3-fold (0.63 log units), on the low side; measured number above the stated range.
By their numbers in this assay, from the lowest: compounds 2 and 1 (each within the scatter of the next); then compound 3.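

At this aromatic carbon, para to a large group, the choice of group can move the number beyond the scatter: in this assay the change from methoxy to dimethylamino gives a 3.7-fold higher number from compound 2 to compound 3 (0.57 log units; beyond the scatter) and the change from hydrogen to dimethylamino gives a 2.8-fold higher number from compound 1 to compound 3 (0.44 log units; beyond the scatter) on the same core. Hydrogen and methoxy had not been told apart at this position, so compound 3 is the first sign that the position is not indifferent to what it carries, and the shift runs towards weaker growth inhibition. Nothing available here accounts for the difference between dimethylamino and methoxy.

The compounds shown do not tell whether a primary amine or a methylamino group at this carbon would stay with compound 3 or with compound 1 and compound 2. They also leave open how dimethylamino would fare on another carbon of the same ring.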